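Swapping the Furan for a Fluoromethoxyphenyl: Expected Permeability

A few compounds are considered here, and "the series" means these few. Any claim that something is new, unique, unknown or untested is made for them only; others in the source may bear on it.

Compound 1, `FC(F)(F)c1ccc(-c2ccc3c(NCCCNCc4ccco4)ccnc3c2)cc1`: 237 10^-6 cm/s
Compound 2, `Fc1ccc(Cc2ccc3c(NCCCNCc4ccco4)ccnc3c2)cc1`: 23 10^-6 cm/s

In an ADME assay for permeability, using PAMPA, with a stated time of 30 min, at pH 7.4 (a higher number here means that the compound crosses the layer faster, a lower number that the compound crosses the layer more slowly), compound 1 gives the higher of the two numbers, separated from compound 2 by the step of a 10-fold lower number from compound 1 to compound 2 (1.01 log units; beyond the scatter). Compound 3, `COc1ccc(F)cc1CNCCCNc1ccnc2cc(-c3ccc(C(F)(F)F)cc3)ccc12`, differs from compound 1 in one place: 5-fluoro-2-methoxyphenyl in place of furan-2-yl on a saturated chain carbon bound to an amine nitrogen. Among the measured compounds shown here, the only measured step alters a different part of the shared core, so no measured step speaks directly to this change. For the measured compounds named here, with compound 1 already at the top of the numbers so far, a step within the scatter is expected: a 1.2-fold lower number from compound 1 to compound 3 (0.07 log units; within the scatter). Compound 3 is therefore expected to give 200 10^-6 cm/s, within 90 10^-6 cm/s to 400 10^-6 cm/s.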

Compound 3, apparent permeability: 237 10^-6 cm/s
Estimate against measurement, compound 3: 1.2-fold (0.07 log units) below; measured number inside the range.
By their numbers in this assay, from the lowest: compound 2; then compounds 1 and 3 (each within the scatter of the next).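

Among the compounds shown here, on the saturated chain carbon bound to an amine nitrogen, the earlier compounds carried only furan-2-yl, so they said nothing about this place. In this assay, 5-fluoro-2-methoxyphenyl in place of furan-2-yl gives no change at the digits printed from compound 1 to compound 3 (within the scatter) and shows that this place accepts a six-membered aromatic ring of 9 heavy atoms in place of a five-membered one of 5 without a readable step. Nothing measured here gives a reason for this result. On these data alone, whether a cyclohexyl group or a pyridine ring at this place would read the same remains open, and so does whether this swap would behave alike with the 4-fluorobenzyl group of compound 2.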